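Menthyl amides at the vanilloid channel: para-phenyl benzamide

The source may report more compounds than this note shows. Statements on the series, on what has been measured and on what is new or still open speak of the compounds shown alone.

In a functional assay on HEK293 cells for agonist activity at transient receptor potential cation channel subfamily V member 1 (Homo sapiens) (a higher number here means a larger maximal response, a lower number a smaller maximal response), compound 1 `Cc1ccc(C(=O)N[C@@H]2C[C@H](C)CC[C@H]2C(C)C)cc1` gives 5.4%. Compound 2 `CCCCCCCC/C=C\CCCCCCCCC(=O)N[C@@H]1C[C@H](C)CC[C@H]1C(C)C` gives 4.4% in this assay; the two numbers lie within the usual scatter of each other, so neither compound is set apart and both sit at a low maximal response. Compound 3 `CC(C)[C@@H]1CC[C@@H](C)C[C@H]1NC(=O)c1ccc(-c2ccccc2)cc1` carries phenyl in place of methyl on an aromatic carbon. Among the measured compounds shown here, no measured pair shows a change of this kind, so its effect is unknown from the present data. Expected is a small step, a number 2.6 percentage points higher from compound 1 to compound 3 (within the scatter), upward if anything and hardly beyond the scatter. Compound 3 is estimated at 8%, in a range from 2% to 25%.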

Compound 3, largest response reached (reported as efficacy), in percent of the reference or control that the assay uses: 7.8%
Compound 3: the middle estimate sits 0.2 percentage points above what was measured; the measured number falls inside the stated range.
By their numbers in this assay, from the lowest: compounds 2, 1 and 3 (each within the scatter of the next).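

In this assay, phenyl in place of methyl on an aromatic carbon, para to a large group, gives a number 2.4 percentage points higher from compound 1 to compound 3 (within the scatter), so at this position the two groups are not told apart. An added six-membered aromatic ring of carbon only is thus compatible with a maximal response that stays low, as for compound 1. Nothing at hand accounts for this result.

Open, on these data alone, is whether an amine or a carboxylic acid at this aromatic carbon would give a response set apart from compound 1. Also open, as far as these compounds go, is whether any change on the shared core lifts the response beyond the scatter.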